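Cytotoxicity Limits Across Three Close Analogues

This account rests on a few compounds, and the source may have more. Where it says the series, first, only, none or still open, it means among the compounds named here.

Compound 1 `COc1cccc(-c2ccc(C(=O)N(Cc3cccc(OCCCCCC(=O)O)c3)C(C)C)cc2)c1`: in an ADME assay on HepG2 cells (Homo sapiens) for cytotoxicity, read by CellTiter-Glo and resazurin assay, with a stated time of 72 h (on this read-out higher numbers stand for an effect only at larger amounts of compound and lower numbers for an effect already at smaller amounts), compound 1 gives > 26000 nM, which is a limit of the assay.
Compound 2 `Cc1nnc(-c2cccc(-c3ccc(C(=O)N(Cc4cccc(OCCCCCC(=O)O)c4)C(C)C)cc3)c2)o1`: in this assay compound 2 gives > 26000 nM, also a limit of the assay.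
Compound 3 `CCOC(=O)CCCCCOc1cccc(CN(C(=O)c2ccc(-c3cccc(-c4nnc(C)o4)c3)cc2)C(C)C)c1`: in this assay compound 3 gives > 26000 nM, again a limit of the assay.

Compound 2 and compound 1 differ in a single place: methoxy in place of 5-methyl-1,3,4-oxadiazol-2-yl on an aromatic carbon. The step that the two limits leave unreadable from compound 2 to compound 1 has no readable size because the limit of > 26000 nM in this assay, at which 3 of the 3 values shown sit, holds both ends of it. Compound 2 and compound 3 differ in their cores by ethyl in place of hydrogen on an oxygen next to a carbonyl group, and the step that the two limits leave unreadable from compound 2 to compound 3 is likewise unreadable because the limit of > 26000 nM in this assay, at which 3 of the 3 values shown sit, covers both compounds.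

Compound 4 `CCOC(=O)CCCCCOc1cccc(CN(C(=O)c2ccc(-c3cccc(OC)c3)cc2)C(C)C)c1` has not yet been measured. It stands to compound 3 as compound 1 stands to compound 2: the change is methoxy in place of 5-methyl-1,3,4-oxadiazol-2-yl on an aromatic carbon, the same change as before, at a place described in identical words. The expectation for compound 4 in this assay is a step that the limit leaves unreadable from compound 3 to compound 4, resting on the earlier step that the two limits leave unreadable from compound 2 to compound 1, which left the read-out at the limit. Compound 4 is therefore estimated at 30000 nM, with a range from 15000 nM to 80000 nM, and it is expected that the assay will once more report only a limit rather than a number.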

Compound 4, half-maximal effective concentration: > 21000 nM
Compound 4: no number, only a limit; the forecaster's own chance of this, stated with the estimate: 85%; the middle value does not contradict the limit.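

Compound 4 gives only a limit of the assay in this assay, and no new step can be read, neither from compound 3 to compound 4 nor from compound 1 to compound 4. Compounds 1, 2, 3 and 4 leave open at what concentration any effect on the cells would appear, and whether methoxy in place of 5-methyl-1,3,4-oxadiazol-2-yl, or ethyl in place of hydrogen, changes the read-out at all.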